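The source may report more compounds than this note shows. Statements on the series, on what has been measured and on what is new or still open speak of the compounds shown alone.

Compound 1, with the structure `COc1cc(-c2nn(-c3ccc(NC(=O)Nc4ccc(Cl)c(C(F)(F)F)c4)cc3)cc2-c2ccncc2)ccc1Cl`, is tested in a functional assay on A375P cells (Homo sapiens) for antiproliferative activity, read by MTT assay, with a stated time of 48 h (a higher number here means a weaker inhibitor, a lower number a stronger inhibitor), where compound 1 gives 14000 nM. Compound 2, with the structure `COc1cc(-c2nn(-c3ccc(NC(=O)c4ccc(Cl)c(Cl)c4)cc3)cc2-c2ccncc2)ccc1Cl`, gives 13000 nM in this assay. The two numbers sit within the scatter of each other, so neither compound can be called the stronger inhibitor on the numbers shown, and the step of a 1.1-fold lower number from compound 1 to compound 2 (0.03 log units; within the scatter), in which the urea of compound 1 becomes a plain amide, changes nothing beyond the scatter.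

Compound 3, with the structure `O=C(Nc1ccc(-n2cc(-c3ccncc3)c(-c3ccc(Cl)c(O)c3)n2)cc1)Nc1ccc(Cl)c(C(F)(F)F)c1`, is not yet measured. It differs from compound 1 in a different part of the molecule: hydrogen in place of methyl on an oxygen on an aromatic ring. For the measured compounds named here, no measured step touches this oxygen; the only step available concerns the urea side of the molecule, and it was within the scatter. There is therefore nothing in the data that points to a change in either direction. The step of no change at the digits printed from compound 1 to compound 3 (within the scatter) is expected to stay within the scatter. Compound 3 is accordingly estimated to give 14000 nM in this assay, with a range from 5000 nM to 40000 nM.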

Compound 3, half-maximal inhibitory concentration: 14900 nM
Compound 3: middle estimate off by 1.1-fold (0.03 log units), on the low side; the range from low to high includes it.
By their numbers in this assay, from the lowest: compounds 2, 1 and 3 (each within the scatter of the next).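

In this assay, putting hydrogen in place of methyl on an oxygen on an aromatic ring gives a 1.1-fold higher number from compound 1 to compound 3 (0.03 log units; within the scatter), so the assay does not tell the methoxy and hydroxy compounds apart. For the compounds shown here, the earlier step changed only the urea side of the molecule, whereas this one gives the first reading at this oxygen: here, the 4-chloro-3-methoxyphenyl and 4-chloro-3-hydroxyphenyl forms cannot be separated, at least on the urea series represented by compound 1 and compound 3. No measurement shown here bears on why the two compounds read alike.

From the compounds shown here alone, with only methyl and hydrogen on this oxygen, it remains open whether an ethyl group or a longer chain there, or an amine in place of the oxygen, would move the number beyond the usual scatter. Going by these compounds, it is also open whether the same swap would read alike on the amide of compound 2, since the hydroxy group appears here only with the urea.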